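The source may hold more compounds than are shown below. What is called first, only, known or untested is meant among the compounds shown, and "the series" means these compounds.

Measured so far in an assay on isolated protein for inhibition of Voltage-dependent T-type calcium channel subunit alpha-1I (Homo sapiens), read by FLIPR; a higher number here means a weaker inhibitor, a lower number a stronger inhibitor:
- compound 1, `O=C(NCC1CCN(Cc2cccnc2)CC1)c1cc(Cl)cc(Cl)c1`, gives 7610 nM
- compound 2, `O=C(NCC1CCN(Cc2ccc(Br)nc2)CC1)c1cc(Cl)cc(Cl)c1`, gives 552 nM
- compound 3, `CCC(C)C(C)CN1CCC(CNC(=O)c2cc(Cl)cc(Cl)c2)CC1`, gives 38 nM

Compound 3 stands lowest of the three numbers in this assay; the nearest is compound 2 and the furthest compound 1, both beyond the scatter. The steps leading to it are large: a 200-fold lower number from compound 1 to compound 3 (2.30 log units; beyond the scatter) and a 15-fold lower number from compound 2 to compound 3 (1.16 log units; beyond the scatter), while within the aromatic pair a 14-fold lower number from compound 1 to compound 2 (1.14 log units; beyond the scatter).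

Compound 4, `CC(C)(C)NC(=O)CN1CCC(CNC(=O)c2cc(Cl)cc(Cl)c2)CC1`, is the next analogue: (tert-butyl)carbamoyl in place of 1,2-dimethylbutyl on a saturated chain carbon bound to an amine nitrogen in a ring. For the measured compounds named here, no measured step covers an amide-bearing substituent at this position; the two steps onto compound 3 only show that the branched alkyl group sits far below either pyridyl group. The new group shares neither the saturated carbon chain of compound 3 nor the aromatic ring of compounds 1 and 2, so the direction is read from compound 3 alone: a loss is expected, of uncertain size, and compound 4 is estimated at 1500 nM, plausibly between 300 nM and 8000 nM, which as a step means a 39-fold higher number from compound 3 to compound 4 (1.60 log units; beyond the scatter).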

Compound 4, half-maximal inhibitory concentration: 22 nM
Beside the measured number, compound 4's estimate is 68-fold (1.83 log units) above it, and the stated range ends above it.
By their numbers in this assay, from the lowest: compounds 4 and 3 (each within the scatter of the next); then compound 2; then compound 1.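

In this assay, the saturated chain carbon bound to an amine nitrogen in a ring carries (tert-butyl)carbamoyl and 1,2-dimethylbutyl with no separation between them (a 1.7-fold lower number from compound 3 to compound 4 (0.24 log units; within the scatter)), although only the former has a hydrogen-bond donor and acceptor. An all-carbon chain is therefore not required here, and the amide-bearing group also stands well clear of both pyridyl groups (a 25-fold lower number from compound 2 to compound 4 (1.40 log units; beyond the scatter); a 350-fold lower number from compound 1 to compound 4 (2.54 log units; beyond the scatter)). No supporting data bear on why these two different groups give such close numbers.

Going by these compounds, whether the amide hydrogen is needed remains open, as does the role of the tert-butyl group, which (methyl)carbamoyl would probe. A carboxylic acid or a primary amine at this position is also untested among the compounds shown.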